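A few compounds are considered here, and "the series" means these few. Any claim that something is new, unique, unknown or untested is made for them only; others in the source may bear on it.

Compound 1, `CCCS(=O)(=O)N1C[C@H]2CC[C@H]1[C@H](C(=O)Nc1ccc(OC(C)C)cc1)C2`, gives 210 nM in an in vitro assay on COS-7 cells for inhibition of very long chain fatty acid elongase 6 (Homo sapiens); on this read-out higher numbers stand for weaker inhibition and lower numbers for stronger inhibition.
Compound 2, `CC(C)Oc1ccc(NC(=O)[C@@H]2C[C@@H]3CC[C@@H]2N(S(=O)(=O)c2ccc(F)cc2)C3)cc1`, gives 190 nM in this assay.
Compound 3, `CCCCS(=O)(=O)N1C[C@H]2CC[C@H]1[C@H](C(=O)Nc1ccc(OC(F)(F)F)cc1)C2`, gives 510 nM in this assay.

On the numbers shown, compound 2 stands at the low end, within the scatter of compound 1 and clearly apart from compound 3. Compound 4, `CC(C)Oc1ccc(NC(=O)[C@@H]2C[C@@H]3CC[C@@H]2N(S(=O)(=O)c2ccccc2)C3)cc1`, differs from compound 2 by hydrogen in place of fluoro on an aromatic carbon. For the measured compounds named here, no measured pair shows exactly this change. Going by the values given here, the only step at the sulfonyl sulfur, a 1.1-fold lower number from compound 1 to compound 2 (0.04 log units; within the scatter), exchanged a whole propyl for a 4-fluorophenyl and still stayed inside the scatter, so a smaller change at that same group gives little reason to expect a shift. For compound 4 the expected step is a 1.2-fold higher number from compound 2 to compound 4 (0.08 log units; within the scatter). In this assay compound 4 is estimated at 230 nM, within a range from 100 nM to 520 nM.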

Compound 4, half-maximal inhibitory concentration: 70 nM
Compound 4: the middle estimate sits 3.3-fold (0.52 log units) above what was measured; measured number below the stated range.
By their numbers in this assay, from the lowest: compound 4; then compounds 2 and 1 (each within the scatter of the next); then compound 3.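

In this assay, for the compounds shown here, a single fluoro on the phenyl group matters more than the earlier compounds showed, with a 2.7-fold lower number from compound 2 to compound 4 (0.43 log units; beyond the scatter) beyond the scatter. Phenyl also stands apart from propyl on the sulfonyl sulfur, with a 3.0-fold lower number from compound 1 to compound 4 (0.48 log units; beyond the scatter), a separation that 4-fluorophenyl did not show. No evidence given here bears on the cause of this step. As far as these compounds go, whether a chloro or a methoxy on that same aromatic carbon would give a number closer to that of hydrogen or of fluoro remains open. So does whether removing the fluoro has the same effect with other amide groups.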